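Cinnamate esters: removing the benzyl from the aromatic oxygen

A few compounds are considered here, and "the series" means these few. Any claim that something is new, unique, unknown or untested is made for them only; others in the source may bear on it.

Compound 1 `COCOc1cc(/C=C/C(=O)OCC(=O)Nc2ccc(OC)cc2)ccc1OCc1ccccc1` carries a methoxymethyl on an aromatic oxygen. In a functional assay on CNE cells (Homo sapiens) for cytotoxicity, read by MTT assay, with a stated time of 72 h (a lower number here means a stronger inhibitor, a higher number a weaker inhibitor), compound 1 gives only the assay limit > 200000 nM. Compound 2 `COc1ccc(NC(=O)COC(=O)/C=C/c2ccc(OCc3ccccc3)c(O)c2)cc1`, with hydrogen in place of methoxymethyl on an oxygen on an aromatic ring, in this assay likewise stops at the limit > 200000 nM. The a step that the two limits leave unreadable from compound 1 to compound 2 cannot be sized, since both values sit at the limit of > 200000 nM in this assay, at which 2 of the 2 values shown sit. Compound 3 `COc1ccc(NC(=O)COC(=O)/C=C/c2ccc(O)c(O)c2)cc1` differs from compound 2 by hydrogen in place of benzyl on an oxygen on an aromatic ring. For the measured compounds named here, no measured step bears on this change, and compound 2 offers only a limit. The step of a number no higher from compound 2 to compound 3 (the limit leaves the size open) is expected to be none beyond the scatter. Compound 3 is therefore estimated at 200000 nM, within 50000 nM to 1000000 nM.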

Compound 3, half-maximal inhibitory concentration: > 200000 nM
Compound 3 ended at the assay's limit; the forecaster's own chance of this, stated with the estimate: 75%; the middle value sits exactly at the limit.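

No step can be read between compound 2 and compound 3, since both stop at a limit and give no number: the limit of > 200000 nM in this assay, at which 3 of the 3 values shown sit.

The compounds shown leave open whether either change on the aromatic oxygen shifts potency in this assay.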